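The source may report more compounds than this note shows. Statements on the series, on what has been measured and on what is new or still open speak of the compounds shown alone.

Measured compounds:
compound 1 `O=C(/C=C/c1ccccc1)c1ccc(N2CCN(c3ccccc3Cl)CC2)cc1`, 4.71%
compound 2 `Cc1ccc(S(=O)(=O)N2CCN(c3ccc(C(=O)/C=C/c4ccccc4)cc3)CC2)cc1`, 30.8%

In a functional assay on the whole organism (strain Kunming) for inhibition, with Mus musculus as the target, with a stated time of 1 h, at a dose of 40 mg/kg by the oral route (on this read-out higher numbers stand for more inhibition at the one dose given (going by the name of the read-out) and lower numbers for less inhibition), compound 2 stands highest of the two numbers, the gap to the other being the step of a number 26.1 percentage points higher from compound 1 to compound 2 (beyond the scatter). Compound 3 `O=C(/C=C/c1ccccc1)c1ccc(N2CCN(S(=O)(=O)c3ccc(Cl)cc3)CC2)cc1` carries the change (chloro in place of methyl on an aromatic carbon). Going by the values given here, no measured step touches this change: the one step known, a number 26.1 percentage points higher from compound 1 to compound 2 (beyond the scatter), exchanges the whole group on an amine nitrogen in a ring and tells nothing about methyl against chloro. With nothing to lean on, the expected step of a number 0.8 percentage points lower from compound 2 to compound 3 (within the scatter) is none beyond the scatter. Compound 3 is therefore estimated at 30%, with a range from 10% to 50%.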

Compound 3, a percentage reported as inhibition, in the whole organism at one dose (the size of the read-out at that dose, not a potency): 46.8%
Compound 3: middle estimate off by 16.8 percentage points, on the low side, and the stated range covers the measured number.
By their numbers in this assay, from the lowest: compound 1; then compound 2; then compound 3.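

In this assay the sulfonyl aryl ring is not a silent place: chloro in place of methyl, para to a large group, gives a number 16 percentage points higher from compound 2 to compound 3 (beyond the scatter). Exchanging 2-chlorophenyl for (4-chlorophenyl)sulfonyl on the ring amine nitrogen gives a number 42.1 percentage points higher from compound 1 to compound 3 (beyond the scatter), so this group now spans a wider range than the first step showed. No data at hand explain the gain from chloro.

On these data alone, it remains open whether the gain is particular to chloro, which bromo, methoxy or an amine on the same aromatic carbon would test. Also open, as far as these compounds go, is whether the aryl ring on the sulfonyl is needed at all, which a plain alkyl chain there would test.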